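This account rests on a few compounds, and the source may have more. Where it says the series, first, only, none or still open, it means among the compounds named here.

The measured compounds:

compound 1, `N#Cc1cccc(/C(CCN2CCN(c3ccccn3)CC2)=N/O)c1`: 13.1 nM
compound 2, `Cc1cc(C)cc(/C(CCN2CCN(c3ccccn3)CC2)=N/O)c1`: 45.8 nM

In a functional assay on HEK293 cells with D(4) dopamine receptor (Homo sapiens) as the target, read by FLIPR (a higher number here means that more compound is needed for the effect, a lower number that less compound is needed), compound 2 gives 45.8 nM, the highest of the two numbers recorded so far. For the measured compounds named here, its nearest neighbour is compound 1, which gives 13.1 nM in this assay; the single measured step runs a 3.5-fold higher number from compound 1 to compound 2 (0.54 log units; beyond the scatter), through an exchange of the aryl group on the carbon that carries the double bond to nitrogen.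

Compound 3, `Cc1ccc(O)c(/C(CCN2CCN(c3ccccn3)CC2)=N/O)c1`, has not yet been measured in this assay. It differs from compound 2 in one place: 2-hydroxy-5-methylphenyl in place of 3,5-dimethylphenyl on a carbon with a double bond to nitrogen. Going by the values given here, only the step of a 3.5-fold higher number from compound 1 to compound 2 (0.54 log units; beyond the scatter) bears on this change, since it is the one recorded exchange at the same aryl position, and it was modest. Among the compounds with values here, no measured compound carries a hydroxyl group on that ring, so the direction cannot be read from the data; a change of similar, modest size in either direction is the most that can be expected.

For compound 3 the expected step from compound 2 is a 1.3-fold lower number from compound 2 to compound 3 (0.12 log units; within the scatter). The estimate for compound 3 in this assay is therefore 35 nM, with a range from 9 nM to 140 nM.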

Compound 3, half-maximal effective concentration: 19.2 nM
Compound 3: middle estimate off by 1.8-fold (0.26 log units), on the high side, and the stated range covers the measured number.
By their numbers in this assay, from the lowest: compounds 1 and 3 (each within the scatter of the next); then compound 2.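

In this assay, 2-hydroxy-5-methylphenyl in place of 3,5-dimethylphenyl gives a 2.4-fold lower number from compound 2 to compound 3 (0.38 log units; beyond the scatter), the first exchange at this position shown to run towards a lower number and again one that lies beyond the scatter. Against the 3-cyanophenyl group of compound 1, the same new group gives a 1.5-fold higher number from compound 1 to compound 3 (0.17 log units; within the scatter), which lies within the scatter: two differently substituted aryl groups, one with a nitrile and the other with a hydroxyl and a methyl, read alike here, while the 3,5-dimethylphenyl group of compound 2 stands apart from both. No available evidence bears on the reason for these differences.

Still open, from the compounds shown here alone, is what the hydroxyl group contributes on its own, and how a methoxy group in its place or an unsubstituted phenyl ring would read on the carbon with a double bond to nitrogen. The compounds shown also leave open how an amine or a carboxylic acid on this aryl ring would read, and whether a longer chain on the same carbon would leave these small differences intact.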